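Carbonyl aryl swap in the nitrophenylhydrazone series

The compounds below may be only part of what the source reports. "The series", "measured", "known", "first", "only" and "open" are said of these compounds alone.

Compound 2 `CC(/C=N/Nc1ccc([N+](=O)[O-])cc1)=N\NC(=O)c1ccc([N+](=O)[O-])cc1` gives 980 nM in a functional assay on cells (Splenocyte, Mus musculus, strain BALB/c) for inhibition, read by scintillation counting and thymidine incorporation, with a stated time of 72 h (a higher number here means a weaker inhibitor, a lower number a stronger inhibitor), and holds the only number shown for the series. Compound 1 `COc1ccc(C(=O)N/N=C(C)/C=N/Nc2ccc([N+](=O)[O-])cc2)cc1` reaches only a limit, > 12000 nM (the limit of > 12000 nM in this assay, at which 1 of the 2 values shown sits). Among the measured compounds shown here, the single measured step, an at least 12-fold lower number from compound 1 to compound 2 (1.08 log units; beyond the scatter), is the one that bears on compound 3 `CC(/C=N/Nc1ccc([N+](=O)[O-])cc1)=N\NC(=O)c1ccccc1N`, which differs from compound 2 by 2-aminophenyl in place of 4-nitrophenyl on a carbonyl carbon. Removing the nitrophenyl again is expected to move the number back upward in this assay, a step of a 6.1-fold higher number from compound 2 to compound 3 (0.79 log units; beyond the scatter). For compound 3 the estimate is 6000 nM, between 1500 nM and 12000 nM, with a real chance of another limit.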

Compound 3, half-maximal inhibitory concentration: 4900 nM
Beside the measured number, compound 3's estimate is 1.2-fold (0.09 log units) above it; the measured number falls inside the stated range.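

Compound 3 shows that a nitro group is not required for a measurable number at this carbonyl carbon, since 2-aminophenyl also gives one: an at least 2.4-fold lower number from compound 1 to compound 3 (0.38 log units; beyond the scatter). Nitro still has the edge over amino in this comparison, with a 5.0-fold higher number from compound 2 to compound 3 (0.70 log units; beyond the scatter). The first step has only a lower bound on its size, and compound 1 remains a limit: the limit of > 12000 nM in this assay, at which 1 of the 3 values shown sits.

The swap changes both the substituent and its place on the ring, and these compounds cannot separate the two. From the compounds shown here alone, how a 4-aminophenyl or an unsubstituted phenyl on the carbonyl carbon would read remains open.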